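Replacing Ethoxy with Chloro on a Shared Core

The source may report more compounds than this note shows. Statements on the series, on what has been measured and on what is new or still open speak of the compounds shown alone.

For the measured compounds named here, in a functional assay on HaCaT cells (Homo sapiens) for antiproliferative activity, read by sulforhodamine B assay, with a stated time of 3 days (a higher number here means a weaker inhibitor, a lower number a stronger inhibitor), compound 2 `CCOc1ccc(OC)c(CCc2ccc(O)c(C(=O)OC)c2)c1` stands at 540 nM as the lower of the two numbers so far, while compound 1 `COC(=O)c1cc(CCc2cc(O)ccc2OC)ccc1O` stands at 8700 nM on the same scale. Compound 3 `COC(=O)c1cc(CCc2cc(Cl)ccc2OC)ccc1O` has not yet been measured. Its change from compound 2 is chloro in place of ethoxy on an aromatic carbon and nothing else. Going by the values given here, one measured step bears on this place: ethyl in place of hydrogen on an oxygen on the aromatic ring gave a 16-fold lower number from compound 1 to compound 2 (1.21 log units; beyond the scatter) as a large change. Among the compounds with values here, no chloro compound has been measured, so this step is only a loose guide. A smaller rise than that step is expected, with a 2.4-fold higher number from compound 2 to compound 3 (0.38 log units; beyond the scatter) as the estimate in this assay for now. For compound 3 the estimated value is 1300 nM within an expected range from 350 nM to 5000 nM in this series.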

Compound 3, half-maximal inhibitory concentration: 6900 nM
Compound 3: the middle estimate sits 5.3-fold (0.72 log units) below what was measured; measured number above the stated range.
By their numbers in this assay, from the lowest: compound 2; then compounds 3 and 1 (each within the scatter of the next).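

In this assay, the ethoxy group on this aromatic carbon now stands apart from two other groups at the same place: chloro in its stead gives a 13-fold higher number from compound 2 to compound 3 (1.11 log units; beyond the scatter), another large step at this position. Chloro and hydroxy are not separated here, with a 1.3-fold lower number from compound 1 to compound 3 (0.10 log units; within the scatter), so of the three groups shown, only ethoxy goes with the clearly lower number. Nothing available here accounts for this difference.

As far as these compounds go, whether this benefit belongs to ethoxy itself or would also come with a methoxy, a propoxy or a longer chain on that oxygen stays open, as does whether an amine or a carboxylic acid on the same carbon would fall with compound 2 or with compound 1 and compound 3. From the compounds shown here alone, what a change elsewhere on the shared core, such as an amide in place of the methyl ester, would do to these differences also remains open.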